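Hydroxy for Methyl on a Cytotoxicity-Limited Core

A few compounds are considered here, and "the series" means these few. Any claim that something is new, unique, unknown or untested is made for them only; others in the source may bear on it.

Compound 1 `CCOC(=O)c1c(-c2cccc(C)c2)[nH]c2cc(OC)ccc2c1=O`: in an ADME assay on Raji cells (Homo sapiens) for cytotoxicity, read by luminescence, with a stated time of 72 h (a lower number here means that less compound is needed, a higher number that more compound is needed for the effect), compound 1 gives > 21500 nM, which is a limit of the assay rather than a number.
Compound 2 `CCOC(=O)c1c(-c2cccc(-c3ccccc3)c2)[nH]c2cc(OC)ccc2c1=O`: in this assay compound 2 gives > 21500 nM, again a limit and not a number.

Going by the values given here, compound 1 therefore stands only at a limit in this assay, and the one further value shown is a limit as well. Among the compounds with values here, the single measured step, a step that the two limits leave unreadable from compound 1 to compound 2, cannot be read in size or direction, since both compounds sit at the limit of > 21500 nM in this assay, at which 2 of the 2 values shown sit. Compound 3 `CCOC(=O)c1c(-c2cccc(O)c2)[nH]c2cc(OC)ccc2c1=O` differs from compound 1 by hydroxy in place of methyl on an aromatic carbon. Within the data shown here, no measured step covers this exchange, and the one step that exists offers no readable size to build on. With both measured compounds at the limit, compound 3 is expected to remain at or beyond that limit too, so the estimated step that the limit leaves unreadable from compound 1 to compound 3 is not expected to be readable. The estimate for compound 3 in this assay is 30000 nM, with an expected range from 10000 nM to 100000 nM.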

Compound 3, half-maximal effective concentration: > 21500 nM
Compound 3 was reported as a limit (the forecaster's own chance of this, stated with the estimate: 80%); the middle value does not contradict the limit.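

Compound 3 adds no readable step: its steps from compound 1 and from compound 2 cannot be read in size or direction, because all three compounds give a limit of the assay rather than a number: the limit of > 21500 nM in this assay, at which 3 of the 3 values shown sit.

The compounds shown leave open whether methyl, phenyl or hydroxy at this place changes the result in this assay.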